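A few compounds are considered here, and "the series" means these few. Any claim that something is new, unique, unknown or untested is made for them only; others in the source may bear on it.

Measured in a functional assay on HT-29 cells (Homo sapiens) for cytotoxicity, read by MTT assay, with a stated time of 6 days; a higher number here means that more compound is needed for the effect, a lower number that less compound is needed:
Compound 1 `O=c1cc(-c2ccc([N+](=O)[O-])cc2)oc2ccc(O)cc12`: > 25 ug/mL, a limit
Compound 2 `COc1cc(-c2cc(=O)c3ccc(O)cc3o2)cc(OC)c1OC`: > 25 ug/mL, a limit

Compound 2 has no numerical value in this assay, only the limit > 25 ug/mL. Going by the values given here, the series so far offers only (the limit of > 25 ug/mL in this assay, at which 2 of the 2 values shown sit), so it contains no measured step. Compound 3 `COc1cc(-c2cc(=O)c3ccc(O)cc3o2)cc(OC)c1O[Si](C)(C)C(C)(C)C` differs from compound 2 in one place: a group of 7 heavy atoms (6 carbon, 1 silicon; no ring) in place of one carbon atom, on an oxygen on an aromatic ring. A methyl leaves and a group of 7 heavy atoms (6 carbon, 1 silicon; no ring) enters, on an oxygen on an aromatic ring. Among the compounds with values here, no measured step bears on this change, so the expectation in this assay is weakly held: a modest move towards less compound needed, or nothing beyond the scatter. The expected change is an at least 1.3-fold lower number from compound 2 to compound 3 (0.14 log units; that floor lies within the scatter). Another result reported only as a limit would be unsurprising. The estimate for compound 3 is 18 ug/mL, with an expected range of 6 ug/mL to 30 ug/mL.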

Compound 3, concentration for half-maximal effect: 1 ug/mL
Compound 3: the middle estimate sits 18-fold (1.26 log units) above what was measured; the measured number lies below the stated range.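

Going by these compounds alone, on the oxygen on an aromatic ring, the exchange of methyl for the group of 7 heavy atoms (6 carbon, 1 silicon; no ring) gives the only measured step in this assay: an at least 25-fold lower number from compound 2 to compound 3 (1.39 log units; beyond the scatter). The earlier compounds sat together at a limit and showed no movement, whereas this position is now shown to be one where the read-out can change beyond the scatter. The true size of the step remains unknown, and the printed figure is only a floor, because compound 2 is itself reported as a limit: the limit of > 25 ug/mL in this assay, at which 2 of the 3 values shown sit.

On these data alone, whether the change follows the silicon atom or the carbon atoms of the entering group remains open, and a free hydroxyl, an ethyl group or a longer alkyl chain on the same oxygen would help separate the two. Also open, as far as these compounds go, is whether the same group would have a comparable effect elsewhere on the shared core.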